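The compounds below may be only part of what the source reports. "The series", "measured", "known", "first", "only" and "open" are said of these compounds alone.

Three compounds were measured in an assay for binding affinity to dual specificity mitogen-activated protein kinase kinase 4 (Homo sapiens), read by KINOMEscan, tested at 100 nM; a higher number here means a weaker effect of the compound at the concentration tested, a lower number a stronger effect:
compound 1 `CCCS(=O)(=O)Nc1ccc(F)c(C(=O)c2n[nH]c3ncc(-c4ccccc4)cc23)c1F` gives 2.4%
compound 2 `CCCS(=O)(=O)Nc1ccc(F)c(C(=O)c2n[nH]c3ncc(-c4cccc(Cl)c4)cc23)c1F` gives 40%
compound 3 `CCCS(=O)(=O)Nc1ccc(F)c(C(=O)c2n[nH]c3ncc(-c4cccc(C)c4)cc23)c1F` gives 15%

Compound 3 holds the second highest of these three numbers. Its nearest neighbour is compound 1, the step between them being a number 12.6 percentage points higher from compound 1 to compound 3 (beyond the scatter); its furthest is compound 2, with a number 25 percentage points lower from compound 2 to compound 3 (beyond the scatter). Compound 4 `CCCS(=O)(=O)Nc1ccc(F)c(C(=O)c2n[nH]c3ncc(-c4ccc(F)cc4C)cc23)c1F` differs from compound 3 by 4-fluoro-2-methylphenyl in place of 3-methylphenyl on an aromatic carbon. Within the data shown here, the measured steps that bear on this are the two substitutions on the same ring, a number 37.6 percentage points higher from compound 1 to compound 2 (beyond the scatter) and a number 12.6 percentage points higher from compound 1 to compound 3 (beyond the scatter), both of which raised the number, while no measured step introduces a fluorine on this ring. A modest rise in this assay is therefore expected, a number 7 percentage points higher from compound 3 to compound 4 (within the scatter). Compound 4 is estimated at 22%, within a range of 6% to 50%.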

Compound 4, a percentage reported as activity, at one concentration (the size of the read-out at that concentration, not a potency): 14%
Compound 4: the middle estimate sits 8 percentage points above what was measured, within the range that was stated.
By their numbers in this assay, from the lowest: compound 1; then compounds 4 and 3 (each within the scatter of the next); then compound 2.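

In this assay, 4-fluoro-2-methylphenyl cannot be told apart from 3-methylphenyl at this position (a number 1 percentage points lower from compound 3 to compound 4 (within the scatter)), so this two-substituent ring is tolerated as well as the single methyl. The new ring still differs from phenyl (a number 11.6 percentage points higher from compound 1 to compound 4 (beyond the scatter)) and from 3-chlorophenyl (a number 26 percentage points lower from compound 2 to compound 4 (beyond the scatter)), and all three substituted rings shown now read above phenyl. No supporting measurement accounts for these steps. The compounds shown leave open how the fluoro and the methyl of 4-fluoro-2-methylphenyl each count alone, and whether an amine or a methoxy group on this ring would read differently.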